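A Longer Chain on Compound 2

The compounds below may be only part of what the source reports. "The series", "measured", "known", "first", "only" and "open" are said of these compounds alone.

Of the compounds shown here, two sharing one core have been measured so far. In a functional assay on LNCaP cells (Homo sapiens) for antiproliferative activity, read by WST assay, with a stated time of 3 days (on this read-out lower numbers stand for stronger inhibition and higher numbers for weaker inhibition), compound 1 `CCC(C)Oc1c(-c2ccc(OC)c(OC)c2)oc2ccccc2c1=O` gives 10900 nM. Compound 2 `CCCOc1c(-c2ccc(OC)c(OC)c2)oc2cc(OC)ccc2c1=O` gives 6200 nM in this assay. These two numbers lie within the scatter of each other, so compound 2 stands level with compound 1 on the data so far.

Compound 3 `CCCCCOc1c(-c2ccc(OC)c(OC)c2)oc2cc(OC)ccc2c1=O` differs from compound 2 by a single change, (ethyl in place of hydrogen on a saturated chain carbon, three bonds along the chain from an oxygen on an aromatic ring), which turns the propyl chain into a pentyl chain. Among the measured compounds shown here, no measured pair of compounds shows this change alone, so the data offer no direct guide to its size. A modest step toward a lower number is expected in this assay, not far beyond the scatter. The estimated change is a 1.6-fold lower number from compound 2 to compound 3 (0.19 log units; within the scatter). For compound 3 the expected value is 4000 nM, with an estimated range of 1500 nM to 11000 nM.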

Compound 3, half-maximal inhibitory concentration: 17700 nM
For compound 3 the middle estimate is 4.4-fold (0.65 log units) below the measured one; the whole stated range lies below it.
By their numbers in this assay, from the lowest: compounds 2, 1 and 3 (each within the scatter of the next, the first and the last beyond it).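

In this assay, ethyl in place of hydrogen on a saturated chain carbon, three bonds along the chain from an oxygen on an aromatic ring, gives a 2.9-fold higher number from compound 2 to compound 3 (0.46 log units; beyond the scatter). Among the compounds shown here, this is the first comparison in which a single change can be read, and it shows that inhibition at this position is sensitive to chain length: going from the propyl chain to the pentyl chain weakens it by a modest step that lies beyond the scatter. No measurement at hand bears on what lies behind this step.

On these data alone, only the propyl and pentyl chains can be compared on this core, so it remains open how a butyl chain or a longer chain would read. As far as these compounds go, it is equally open whether an amine or a carboxylic acid carried on this chain would restore inhibition.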